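Aminothiophene series: ester in place of benzoyl at compound 4

The source may hold more compounds than are shown below. What is called first, only, known or untested is meant among the compounds shown, and "the series" means these compounds.

Compound 1 `Nc1scc(-c2cccc(C(F)(F)F)c2)c1C(=O)c1ccccc1` — in a functional assay on CHO-K1 cells for agonist activity at adenosine receptor A1 (Homo sapiens), read by GTPgammaS binding (a higher number here means that more compound is needed for the effect, a lower number that less compound is needed), compound 1 gives 15.8 uM.
Compound 2 `CC(=O)c1ccc(-c2sc(N)c(C(=O)c3ccccc3)c2-c2cccc(C(F)(F)F)c2)cc1` — for compound 2 this assay returns only a limit, > 10 uM.
Compound 3 `Nc1sc(-c2ccc([N+](=O)[O-])cc2)c(-c2cccc(C(F)(F)F)c2)c1C(=O)c1ccccc1` — for compound 3 this assay again returns only a limit, > 10 uM.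

Compound 2 stands at a limit, not at a number, and the set is dominated by the limit of > 10 uM in this assay, at which 2 of the 3 values shown sit. Among the compounds with values here, none of the measured steps is readable: a step that the limit leaves unreadable from compound 1 to compound 2, a step that the limit leaves unreadable from compound 1 to compound 3, and a step that the two limits leave unreadable from compound 2 to compound 3. Compound 4 `CCOC(=O)c1c(N)sc(-c2ccc(C(C)=O)cc2)c1-c1cccc(C(F)(F)F)c1` differs from compound 2 by ethoxy in place of phenyl on a carbonyl carbon. Within the data shown here, no measured step touches the carbonyl carbon; all three concern the aromatic carbon. The expectation therefore rests only on the limit of compound 2, and compound 4 is estimated at 20 uM (range 5 uM to 80 uM), so the estimated step from compound 2 to compound 4 is a step that the limit leaves unreadable from compound 2 to compound 4.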

Compound 4, concentration for half-maximal effect: > 10 uM
Compound 4 was reported as a limit; the forecaster's own chance of this, stated with the estimate: 70%; the middle value is on the limit's open side.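

Within the data shown here, compound 2 and compound 4 both return only limits in this assay, so no step between them can be read: the limit of > 10 uM in this assay, at which 3 of the 4 values shown sit.
The compounds shown leave open whether ethoxycarbonyl in place of benzoyl shifts the concentration needed at all.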